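From methyl to dimethylamino: will a number appear?

The compounds below may be only part of what the source reports. "The series", "measured", "known", "first", "only" and "open" are said of these compounds alone.

Measured in a functional assay on HT-29 cells (Homo sapiens) for inhibition; a higher number here means a weaker inhibitor, a lower number a stronger inhibitor:
Compound 1 `CC(=O)Oc1ccc(/C=C/c2ccc3ccccc3c2)cc1`: > 5000 nM
Compound 2 `FC(F)(F)Oc1ccc(/C=C/c2ccc3ccccc3c2)cc1`: > 5000 nM
Compound 3 `Cc1ccc(/C=C/c2ccc3ccccc3c2)cc1`: > 5000 nM

Compound 3 stands at > 5000 nM, which is a limit of the assay and not a number. The other two entries are limits as well, and the set as a whole shows (the limit of > 5000 nM in this assay, at which 3 of the 3 values shown sit).

Compound 4 `CN(C)c1ccc(/C=C/c2ccc3ccccc3c2)cc1` keeps the shared core and carries dimethylamino in place of methyl on an aromatic carbon, para to a large group: dimethylamino in place of methyl on an aromatic carbon.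

Three measured steps change the group at this same place: a step that the two limits leave unreadable from compound 1 to compound 2, a step that the two limits leave unreadable from compound 1 to compound 3 and a step that the two limits leave unreadable from compound 2 to compound 3. None of them has a readable size, so they offer no size to carry over. The most likely outcome in this assay is therefore no readable change, and any number that did appear would be expected on the stronger side of the limit. The expected step is a step that the limit leaves unreadable from compound 3 to compound 4. For compound 4 the estimate is 7000 nM, with an expected range from 2000 nM to 20000 nM.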

Compound 4, half-maximal inhibitory concentration: 3660 nM
Compound 4: the middle estimate sits 1.9-fold (0.28 log units) above what was measured; measured number inside the range.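

In this assay, within the data shown here, compound 4 gives 3660 nM as the only value of the four that is a number and not a limit, so a group at this position can bring a reading into the measurable range. Going by these compounds, the steps to it are an at least 1.3-fold lower number from compound 3 to compound 4 (0.13 log units; that floor lies within the scatter) and an at least 1.3-fold lower number from compound 2 to compound 4 (0.13 log units; that floor lies within the scatter) and an at least 1.3-fold lower number from compound 1 to compound 4 (0.13 log units; that floor lies within the scatter) and each of these is only a floor, so the true size of the change from methyl, trifluoromethoxy or acetoxy to dimethylamino stays unknown. The other three entries are limits and not numbers: the limit of > 5000 nM in this assay, at which 3 of the 4 values shown sit.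

Still open, on these data alone, is whether the number belongs to dimethylamino alone or would also appear with other nitrogen groups at this place. A primary amine or diethylamino, with its longer chains on the nitrogen, would be the next groups to compare.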